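This account rests on a few compounds, and the source may have more. Where it says the series, first, only, none or still open, it means among the compounds named here.

Compound 2 `COc1ccc(C(=O)/C=C/c2ccc(OCc3cn(Cc4ccccc4F)nn3)cc2)cc1` is the lower of the two measured compounds in a functional assay on A549 cells (Homo sapiens) for inhibition, read by MTT assay, with a stated time of 48 h, tested at 10 uM; a higher number here means more inhibition of growth at the concentration tested, a lower number less inhibition of growth: compound 2 gives 21%, while compound 1 `COc1ccc(C(=O)/C=C/c2ccc(OCc3cn(Cc4ccccc4Br)nn3)cc2)cc1` gives 52%. Among the measured compounds shown here, the one measured step, a number 31 percentage points lower from compound 1 to compound 2 (beyond the scatter), is the only change with a recorded effect so far. Compound 3 `COc1ccc(C(=O)/C=C/c2ccc(OCc3cn(Cc4cccc(F)c4)nn3)cc2)cc1` is not yet measured. It differs from compound 2 by 3-fluorophenyl in place of 2-fluorophenyl on a saturated chain carbon bound to an aromatic nitrogen. For the measured compounds named here, no measured step covers this kind of change: the step from compound 1 to compound 2 exchanged one halogen for another, whereas here the same fluorine is kept and only its place on the ring is changed, with nothing else altered. With nothing in the measured pair to point either way, the expected step of a number 4 percentage points higher from compound 2 to compound 3 (within the scatter) is one that does not go beyond the scatter. Compound 3 is therefore estimated at 25% in this assay, within a range from 8% to 45%, a wide span that reflects how little the two measured numbers constrain this particular change.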

Compound 3, percent growth inhibition at one concentration: 56%
Compound 3: middle estimate off by 31 percentage points, on the low side; the measured number lies above the stated range.
By their numbers in this assay, from the lowest: compound 2; then compounds 1 and 3 (each within the scatter of the next).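

In this assay, the place of the fluorine proves to matter on its own: going from 2-fluorobenzyl to 3-fluorobenzyl, with nothing else altered, gives a number 35 percentage points higher from compound 2 to compound 3 (beyond the scatter) and is printed as a large step. The low number of compound 2 therefore cannot be read as belonging to fluorine as such, as the halogen exchange alone might have suggested, but belongs to 2-fluorophenyl in particular. The 3-fluorophenyl and 2-bromophenyl groups, by contrast, are not told apart at this position, with a number 4 percentage points higher from compound 1 to compound 3 (within the scatter), and nothing shown here offers any explanation for either step.

Bromine appears only in the 2-bromophenyl group, so whether its number also depends on its place on the ring stays open, as does the standing of an unsubstituted phenyl group or a chlorophenyl group on the same saturated chain carbon. All three numbers come from growth inhibition at a single concentration, so they leave open how compound 1 and compound 3 would compare across a range of concentrations.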